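This account rests on a few compounds, and the source may have more. Where it says the series, first, only, none or still open, it means among the compounds named here.

In a toxicity assay on MT4 cells (Homo sapiens) for cytotoxicity, read by MTT assay (a lower number here means that less compound is tolerated, a higher number that more compound is tolerated), compound 1 `Cc1cc(-c2ccccc2)cc(C)c1Oc1cc(N)nc(Nc2ccc(C#N)cc2)n1` gives 25600 nM and compound 2 `Cc1cc(-c2cccc(Cl)c2)cc(C)c1Oc1cc(N)nc(Nc2ccc(C#N)cc2)n1` gives 22300 nM so these two stand within the usual scatter of each other. The next change leads to compound 3 `Cc1cccc(-c2cc(C)c(Oc3cc(N)nc(Nc4ccc(C#N)cc4)n3)c(C)c2)c1` and puts methyl in place of chloro on an aromatic carbon. For the measured compounds named here, only one measured step bears on this (a 1.1-fold lower number from compound 1 to compound 2 (0.06 log units; within the scatter)) and it put chloro in place of hydrogen on an aromatic carbon. Going by the values given here, with so small a step as the only guide, the change expected in this assay stays within the scatter (a 1.1-fold higher number from compound 2 to compound 3 (0.03 log units; within the scatter)). Compound 3 is estimated at 24000 nM (expected range 12000 nM to 45000 nM).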

Compound 3, half-maximal cytotoxic concentration: 27600 nM
Beside the measured number, compound 3's estimate is 1.2-fold (0.06 log units) below it; the measured number falls inside the stated range.
By their numbers in this assay, from the lowest: compounds 2, 1 and 3 (each within the scatter of the next).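

In this assay, methyl in place of chloro gives a 1.2-fold higher number from compound 2 to compound 3 (0.09 log units; within the scatter), and methyl in place of hydrogen gives a 1.1-fold higher number from compound 1 to compound 3 (0.03 log units; within the scatter). This aromatic carbon, meta to a large group, has now carried hydrogen, chloro and methyl, and all three compounds stand within the scatter of one another, so the tolerated concentration does not separate these groups. Nothing measured here offers an explanation for this.

On these data alone, whether an amine, a carboxylic acid or a longer chain at this position would also stay within the scatter remains open. So does whether methyl and chloro would read the same on other carbons of this ring.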